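This account rests on a few compounds, and the source may have more. Where it says the series, first, only, none or still open, it means among the compounds named here.

Compound 3 `CN(Cc1ccc(OCCCNC(=N)N)cc1)c1nc2ccc(Oc3ccccc3)cc2s1` sits second highest of the three numbers in an assay on cells for inhibition of Voltage-dependent T-type calcium channel subunit alpha-1H (Homo sapiens), read by FLIPR and calcium flux, with stated times of 600 s and 300 s (a higher number here means a weaker inhibitor, a lower number a stronger inhibitor), where compound 3 gives 498000 nM. Compound 2 `CN(Cc1ccc(OCCCNC(=N)N)cc1)c1nc2ccc(Oc3ccc(F)cc3)cc2s1` gives 521000 nM, and the step of a 1.0-fold lower number from compound 2 to compound 3 (0.02 log units; within the scatter) lies within the scatter. Compound 1 `N=C(N)NCCCOc1ccc(CNc2nc3ccc(Oc4cccc(C(F)(F)F)c4)cc3s2)cc1` gives 270000 nM, and its two differences from compound 3 leave the two values within the scatter of each other. Compound 4 `CN(Cc1ccc(OCCCNC(=N)N)cc1)c1nc2ccc(Oc3cccc(C(F)(F)F)c3)cc2s1` differs from compound 3 by trifluoromethyl in place of hydrogen on an aromatic carbon. Going by the values given here, no measured step isolates this change; the only step, a 1.0-fold lower number from compound 2 to compound 3 (0.02 log units; within the scatter), was flat, while compound 1, which also carries the trifluoromethyl, reads somewhat lower. Compound 4 is therefore expected to show a 1.5-fold lower number from compound 3 to compound 4 (0.18 log units; within the scatter), a small lowering, with an estimated value of 330000 nM and a range from 150000 nM to 700000 nM.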

Compound 4, half-maximal inhibitory concentration: 771000 nM
Compound 4: the middle estimate sits 2.3-fold (0.37 log units) below what was measured, and the stated range ends below it.
By their numbers in this assay, from the lowest: compounds 1, 3, 2 and 4 (each within the scatter of the next, the first and the last beyond it).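

On the phenoxy ring, trifluoromethyl in place of hydrogen (a 1.5-fold higher number from compound 3 to compound 4 (0.19 log units; within the scatter)) and 3-(trifluoromethyl)phenyl in place of 4-fluorophenyl (a 1.5-fold higher number from compound 2 to compound 4 (0.17 log units; within the scatter)) both stay within the scatter in this assay, so this ring change does not separate these compounds. The change that does register lies on the nitrogen, where methyl in place of hydrogen gives a modest step (a 2.9-fold higher number from compound 1 to compound 4 (0.46 log units; beyond the scatter)), so the lower reading of compound 1 goes with its hydrogen there, not with its trifluoromethyl. No evidence is available to explain this step.

Going by these compounds, whether an amine or a carboxylic acid on this ring would read differently remains open, as does whether an ethyl group on that nitrogen would go further than methyl.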